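Thiophene in Place of Fluorophenyl: an Expected Small Step

This account rests on a few compounds, and the source may have more. Where it says the series, first, only, none or still open, it means among the compounds named here.

Three compounds have been measured in a functional assay on FM3A cells (Mus musculus) for inhibition, read by cell counting, with a stated time of 2 days; on this read-out lower numbers stand for stronger inhibition and higher numbers for weaker inhibition:

Compound 1 `CCc1ccc(-c2nn3cc(-c4cccc(N)c4)nc3s2)cc1`: 8200 nM
Compound 2 `C=C(Br)C(=O)Nc1cccc(-c2cn3nc(-c4ccc(F)cc4)sc3n2)c1`: 610 nM
Compound 3 `Nc1cccc(-c2cn3c(-c4ccccc4)csc3n2)c1`: 34000 nM

Compound 2 gives the lowest number of the three; compound 1 sits beyond the scatter above it, and compound 3 further still. Compound 4 `C=C(Br)C(=O)Nc1cccc(-c2cn3nc(-c4cccs4)sc3n2)c1` has not yet been measured. It differs from compound 2 by thiophen-2-yl in place of 4-fluorophenyl on an aromatic carbon. Going by the values given here, no pair of measured compounds that differ in one place is available, so the size of this step cannot be read from the measured data. A change of this kind is expected to move the number only modestly, likely within the scatter, in either direction. For compound 4 the estimated value in this assay is 800 nM, with a range from 250 nM to 2500 nM. The expected step is a 1.3-fold higher number from compound 2 to compound 4 (0.12 log units; within the scatter).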

Compound 4, half-maximal inhibitory concentration: 370 nM
For compound 4 the middle estimate is 2.2-fold (0.33 log units) above the measured one, within the range that was stated.
By their numbers in this assay, from the lowest: compounds 4 and 2 (each within the scatter of the next); then compound 1; then compound 3.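

On this aromatic carbon, thiophen-2-yl in place of 4-fluorophenyl gives a 1.6-fold lower number from compound 2 to compound 4 (0.22 log units; within the scatter) in this assay. Going by these compounds alone, this is the first step read at this position, and it shows that a five-membered aromatic ring with 1 hetero atom and a six-membered aromatic ring of carbon only cannot be told apart here. Nothing at hand offers an explanation for this.

On these data alone, whether a carboxylic acid or a morpholine on this carbon would keep the number in this range remains open. So does whether the same exchange behaves alike on the cores of compound 1 and compound 3.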